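The compounds below may be only part of what the source reports. "The series", "measured", "known", "first", "only" and "open" are said of these compounds alone.

Compounds measured in a functional assay on MGC-803 cells (Homo sapiens) for antiproliferative activity, read by CCK-8 assay, with a stated time of 72 h; a lower number here means a stronger inhibitor, a higher number a weaker inhibitor:
- compound 1 `COc1ccn2c(-c3ccc(NC(=O)c4ccc([N+](=O)[O-])o4)cc3)cnc2c1`: 860 nM
- compound 2 `COc1ccn2c(-c3ccc(NC(=O)c4ccc([N+](=O)[O-])o4)cc3OC)cnc2c1`: > 20000 nM, a limit of the assay

Within the data shown here, compound 1 is the only compound with a number in this assay. Among the measured compounds shown here, the single other value, for compound 2, is a limit (the limit of > 20000 nM in this assay, at which 1 of the 2 values shown sits). The step of an at least 23-fold higher number from compound 1 to compound 2 (1.36 log units; beyond the scatter) shows that adding a methoxy on the ring bearing the amide nitrogen pushed the value out of the measurable range.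

Compound 3 `COc1ccn2c(-c3ccc(NC(=O)c4ccc([N+](=O)[O-])o4)c(C(F)(F)F)c3)cnc2c1` differs from compound 1 by trifluoromethyl in place of hydrogen on an aromatic carbon. For the measured compounds named here, only the step from compound 1 to compound 2 bears on it, and that step was large. A weaker inhibitor than compound 1 is therefore expected, though not necessarily beyond the limit. Compound 3 is estimated at 5000 nM, with a range of 1200 nM to 20000 nM, corresponding to an expected step of a 5.8-fold higher number from compound 1 to compound 3 (0.76 log units; beyond the scatter).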

Compound 3, half-maximal inhibitory concentration: 2910 nM
Compound 3: the middle estimate sits 1.7-fold (0.24 log units) above what was measured, within the range that was stated.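

The trifluoromethyl group, placed on an aromatic carbon ortho to a large group and meta to a large group, leaves a measurable value in this assay, with a 3.4-fold higher number from compound 1 to compound 3 (0.53 log units; beyond the scatter). A substituent on this ring therefore costs activity here without necessarily carrying the compound out of the measurable range, and the cost at this position is modest. Compound 2 remains a limit of the assay, so its step gives only a bound and no size for comparison: the limit of > 20000 nM in this assay, at which 1 of the 3 values shown sits.

The methoxy of compound 2 and the trifluoromethyl of compound 3 differ both in group and in ring carbon, so the effects of group and place cannot be separated. Going by these compounds, whether a fluorine, a methyl or an amine at the carbon used in compound 3 would give a smaller or larger step remains open.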